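Swapping the benzyl ring substituent in a bombesin receptor series

A few compounds are considered here, and "the series" means these few. Any claim that something is new, unique, unknown or untested is made for them only; others in the source may bear on it.

Three measured compounds share one core and differ only in the group hanging from the imidazole ring. Compound 1 `O=C(O)c1ccccc1-c1ccc(CCc2ncc(C3CCCCC3)[nH]2)cc1` carries cyclohexyl there and gives 375 nM in an in vitro functional assay on cells for agonist activity at Bombesin receptor subtype-3 (Homo sapiens), read by luminescence and calcium flux; on this read-out higher numbers stand for an effect only at larger amounts of compound and lower numbers for an effect already at smaller amounts. Compound 2 `O=C(O)c1ccccc1-c1ccc(CCc2ncc(CC3CCOCC3)[nH]2)cc1` carries (oxan-4-yl)methyl and gives 338 nM in this assay. Compound 3 `O=C(O)c1ccccc1-c1ccc(CCc2ncc(Cc3ccccc3Cl)[nH]2)cc1` carries 2-chlorobenzyl and gives 292 nM in this assay. Compound 3 has the smallest of the three numbers, yet the steps of a 1.3-fold lower number from compound 1 to compound 3 (0.11 log units; within the scatter) and a 1.2-fold lower number from compound 2 to compound 3 (0.06 log units; within the scatter) are within the scatter, as is a 1.1-fold lower number from compound 1 to compound 2 (0.05 log units; within the scatter), so none of the three can be set apart from the others.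

Compound 4 `N#Cc1ccc(Cc2cnc(CCc3ccc(-c4ccccc4C(=O)O)cc3)[nH]2)cc1` is not yet measured. It differs from compound 3 by 4-cyanophenyl in place of 2-chlorophenyl on a saturated chain carbon bound to an aromatic carbon. Within the data shown here, no measured step exchanges one substituted phenyl for another; the nearest comparison is the step from an oxan-4-yl to a 2-chlorophenyl, a 1.2-fold lower number from compound 2 to compound 3 (0.06 log units; within the scatter), which stayed within the scatter, as did the two steps from cyclohexyl. Since three quite different groups at this position all gave numbers within the scatter of one another, the step of a 1.1-fold higher number from compound 3 to compound 4 (0.04 log units; within the scatter) is expected to stay within the scatter as well. Compound 4 is therefore estimated at 320 nM, with a range from 120 nM to 900 nM.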

Compound 4, half-maximal effective concentration: 5890 nM
Beside the measured number, compound 4's estimate is 18-fold (1.26 log units) below it; measured number outside the range, above it.
By their numbers in this assay, from the lowest: compounds 3, 2 and 1 (each within the scatter of the next); then compound 4.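

This position is less forgiving than the first three compounds suggested. In this assay, cyclohexyl, (oxan-4-yl)methyl and 2-chlorobenzyl remain within the scatter of one another, while 4-cyanobenzyl stands clearly apart from all three (a 20-fold higher number from compound 3 to compound 4 (1.30 log units; beyond the scatter); a 17-fold higher number from compound 2 to compound 4 (1.24 log units; beyond the scatter); a 16-fold higher number from compound 1 to compound 4 (1.20 log units; beyond the scatter)), and all three steps are beyond the scatter. The sharpest contrast is between compound 3 and compound 4: both carry a six-membered aromatic ring of carbon only on the saturated chain carbon, so the presence of such a ring does not by itself set the number, and no measurement here gives a reason for the large step.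

The change from 2-chlorophenyl to 4-cyanophenyl swaps the chlorine for a nitrile and also alters the substituent's printed ring position, so the compounds shown cannot separate these two changes. A 4-chlorobenzyl or a 2-cyanobenzyl group would help to tell them apart, showing whether the large step follows the nitrile, its position on the ring, or only the two together.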